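The source may report more compounds than this note shows. Statements on the series, on what has been measured and on what is new or still open speak of the compounds shown alone.

Measured so far in a functional assay on Hs-578T cells (Homo sapiens) for inhibition; a higher number here means a weaker inhibitor of growth, a lower number a stronger inhibitor of growth:

compound 1 `COc1cccc(/C=C/c2ccc(S(N)(=O)=O)cc2)c1` gives 25500 nM
compound 2 `NS(=O)(=O)c1ccc(/C=C/c2ccc(F)cc2)cc1` gives 23700 nM

Compound 2 lies within the scatter of compound 1, so the pair sets a single level without an order. Compound 3 `CN(C)c1ccc(/C=C/c2ccc(S(N)(=O)=O)cc2)cc1` remains unmeasured and has dimethylamino in place of fluoro on an aromatic carbon relative to compound 2. Among the measured compounds shown here, the series holds no measured step between compounds, so the expectation rests on this structural change alone. A moderate move towards stronger growth inhibition is expected, with a 2.4-fold lower number from compound 2 to compound 3 (0.37 log units; beyond the scatter) as the estimated step in this assay for now. The estimated value for compound 3 is 10000 nM within an expected range from 2500 nM to 40000 nM at this stage.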

Compound 3, concentration for 50% growth inhibition: 3030 nM
Estimate against measurement, compound 3: 3.3-fold (0.52 log units) above; low and high end bracket the measured number.
By their numbers in this assay, from the lowest: compound 3; then compounds 2 and 1 (each within the scatter of the next).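

In this assay, the aromatic carbon para to a large group responds to the substituent: dimethylamino in place of fluoro gives a 7.8-fold lower number from compound 2 to compound 3 (0.89 log units; beyond the scatter). Among the compounds shown here, this is the first step that lies beyond the scatter, whereas the earlier compounds set only a single level. Nothing measured here accounts for the step.

Still open, on these data alone, is whether a primary amine or diethylamino at the same place would keep this step. A single change at this position also cannot show how far the trend extends to other groups.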